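Replacing the ethylphenyl amide with a bromopyridyl amide

A few compounds are considered here, and "the series" means these few. Any claim that something is new, unique, unknown or untested is made for them only; others in the source may bear on it.

Of the compounds shown here, three sharing one core have been measured in an assay on CHO cells, read by calcium flux; on this read-out lower numbers stand for stronger inhibition and higher numbers for weaker inhibition. Compound 1 `CCc1ccc(NC(=O)c2csc(Cc3c(Cl)cccc3Cl)n2)cc1` gives 810 nM, the highest number among the three. Compound 2 `O=C(Nc1ccc(C(F)(F)F)cc1)c1csc(Cc2c(Cl)cccc2Cl)n1` gives 140 nM in this assay, and compound 3 `O=C(Nc1ccc(C(F)(F)C(F)(F)F)cc1)c1csc(Cc2c(Cl)cccc2Cl)n1` gives 290 nM. The two steps away from compound 1 both lower the number: a 5.8-fold lower number from compound 1 to compound 2 (0.76 log units; beyond the scatter), and a 2.8-fold lower number from compound 1 to compound 3 (0.45 log units; beyond the scatter). Between the two fluorinated compounds, a 2.1-fold higher number from compound 2 to compound 3 (0.32 log units; beyond the scatter).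

Compound 4 `O=C(Nc1ccc(Br)cn1)c1csc(Cc2c(Cl)cccc2Cl)n1` has not yet been measured in this assay. It differs from compound 1 in one place: 5-bromopyridin-2-yl in place of 4-ethylphenyl on an amide-type nitrogen. Among the measured compounds shown here, none of the measured steps exchanges the whole ring on the amide-type nitrogen; they only vary the group on the aromatic carbon of the 4-ethylphenyl. Those steps do show that compound 1 is the weakest of the set and that changes at this end of the molecule have so far moved the number only modestly. A step of similar modest size, downward or none beyond the scatter, is therefore the expectation for compound 4, with little to anchor it.

Compound 4 is estimated at 450 nM in this assay, within a range of 120 nM to 1700 nM, which corresponds to an expected step of a 1.8-fold lower number from compound 1 to compound 4 (0.26 log units; within the scatter).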

Compound 4, half-maximal inhibitory concentration: > 4000 nM
Compound 4 was reported as a limit; the forecaster's own chance of this, stated with the estimate: 5%; middle value at least 8.8-fold (0.94 log units) from the limit.
By their numbers in this assay, from the lowest: compound 2; then compound 3; then compound 1. At a limit, above all of these: compound 4.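

In this assay, compound 4 is reported only as a limit and not as a number: the limit of > 4000 nM in this assay, at which 1 of the 4 values shown sits. Putting 5-bromopyridin-2-yl in place of 4-ethylphenyl on the amide-type nitrogen gives an at least 4.9-fold higher number from compound 1 to compound 4 (0.69 log units; beyond the scatter), and this is the only step shown that leaves compound 1 in the upward direction, whereas the steps to compound 2 and compound 3 both lower the number. Among the compounds shown here, those earlier compounds keep the six-membered aromatic ring of carbon only and vary just the group it carries, so compound 4 adds what they could not show: at this position, a change that brings in a ring hetero atom and a bromine can cost more than any of the earlier steps gained.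

The exchange alters the ring and its substituent at once, so the compounds shown cannot say whether the ring nitrogen, the bromine or the two together account for the rise, and how far the true value lies past the limit stays unknown. A 4-bromophenyl group or a 5-ethylpyridin-2-yl group on the amide-type nitrogen would pull these two changes apart.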